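Rearranging the Dihydroxyphenyl Group, from Compound 2 to Compound 3

A few compounds are considered here, and "the series" means these few. Any claim that something is new, unique, unknown or untested is made for them only; others in the source may bear on it.

In a toxicity assay on cells (Fibroblast, Homo sapiens) for cytotoxicity (on this read-out higher numbers stand for weaker inhibition and lower numbers for stronger inhibition), compound 1 `CC(/C=C/C1=CCCCC1(C)C)=C\C=C\C(C)=C\COC(=O)c1c(O)cccc1O` gives 14000 nM, while compound 2 `CC(/C=C/C1=CCCCC1(C)C)=C\C=C\C(C)=C\COC(=O)c1ccc(O)cc1O` gives 120000 nM, the higher of the two numbers. Compound 3 `CC(/C=C/C1=CCCCC1(C)C)=C\C=C\C(C)=C\COC(=O)c1cccc(O)c1O` carries 2,3-dihydroxyphenyl in place of 2,4-dihydroxyphenyl on a carbonyl carbon. Among the measured compounds shown here, the only measured step bearing on this, an 8.6-fold higher number from compound 1 to compound 2 (0.93 log units; beyond the scatter), is a modest one that also exchanges one dihydroxyphenyl group for another at that place. A similar or smaller move is therefore expected, and compound 2 at 120000 nM leaves a lower number as the likelier direction. The estimated step is a 3.0-fold lower number from compound 2 to compound 3 (0.48 log units; beyond the scatter). For compound 3 the expected value is 40000 nM, within a range of 12000 nM to 120000 nM.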

Compound 3, half-maximal inhibitory concentration: < 10000 nM
Compound 3: only a limit was reported; the forecaster's own chance of this, stated with the estimate: 10%; middle value at least 4.0-fold (0.60 log units) away from the limit.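

Exchanging 2,4-dihydroxyphenyl for 2,3-dihydroxyphenyl on a carbonyl carbon, with the same atoms joined differently, produces a large change (an at least 12-fold lower number from compound 2 to compound 3 (1.07 log units; beyond the scatter)), so compound 2 now stands apart from both other compounds. Compound 3 and compound 1 cannot be ordered, as the floor of their step lies within the scatter (an at least 1.4-fold lower number from compound 1 to compound 3 (0.14 log units; that floor lies within the scatter)). Compound 3 is reported only as a limit: the limit of < 10000 nM in this assay, at which 1 of the 3 values shown sits.

From the compounds shown here alone, how far compound 3 extends past that limit remains open. So does whether an amine or a methoxy group in place of one hydroxyl group would preserve this number.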